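A Second Chloro on the 3-Chlorophenyl Compound

A few compounds are considered here, and "the series" means these few. Any claim that something is new, unique, unknown or untested is made for them only; others in the source may bear on it.

In a toxicity assay on J774.A1 cells (Mus musculus) for cytotoxicity, read by SYBR Green assay, with a stated time of 1 h (on this read-out higher numbers stand for an effect only at larger amounts of compound and lower numbers for an effect already at smaller amounts), compound 1 `CN(C)c1ccc2cc(-c3ccccc3Cl)c(N)nc2c1`, which carries a 2-chlorophenyl group, gives 2400 nM. Compound 2 `CN(C)c1ccc2cc(-c3ccccc3Br)c(N)nc2c1`, with 2-bromophenyl, gives 12000 nM, and compound 3 `CN(C)c1ccc2cc(-c3cccc(Cl)c3)c(N)nc2c1`, with 3-chlorophenyl, gives 13000 nM. Compound 3 therefore stands at the high end of the numbers, within the scatter of compound 2 but clear of compound 1.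

Compound 4 `CN(C)c1ccc2cc(-c3cc(Cl)ccc3Cl)c(N)nc2c1` differs from compound 3 by chloro in place of hydrogen on an aromatic carbon, ortho to a large group and para to a chloro group. It thus combines the chloro of compound 3 with one placed as in compound 1. The closest guide is a 5.4-fold higher number from compound 1 to compound 3 (0.73 log units; beyond the scatter), which suggests a lower number. Compound 2 goes against any general rule, since a 5.0-fold higher number from compound 1 to compound 2 (0.70 log units; beyond the scatter) shows that its 2-bromophenyl group does not share the low number of compound 1. A modest move is expected, and the estimated step is a 2.6-fold lower number from compound 3 to compound 4 (0.41 log units; beyond the scatter). For compound 4 the estimate is 5000 nM, with an expected range of 1800 nM to 14000 nM.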

Compound 4, half-maximal effective concentration: 9800 nM
Estimate against measurement, compound 4: 2.0-fold (0.29 log units) below; the range from low to high includes it.
By their numbers in this assay, from the lowest: compound 1; then compounds 4, 2 and 3 (each within the scatter of the next).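

In this assay, chloro in place of hydrogen, ortho to a large group and para to a chloro group, leaves the number within the scatter (a 1.3-fold lower number from compound 3 to compound 4 (0.12 log units; within the scatter)). The low number of compound 1 also does not carry over to the dichloro compound, since adding the chloro of compound 3 to compound 1 raises the number beyond the scatter (a 4.1-fold higher number from compound 1 to compound 4 (0.61 log units; beyond the scatter)); a chloro placed as in compound 1 is therefore not enough for that low number among these compounds. Nothing available accounts for either step.

Going by these compounds, whether a methoxy group or an amine at this place would leave the number as little changed as chloro does remains open. So does whether the same chloro would shift the number of compound 2, which carries the 2-bromophenyl group.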